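A few compounds are considered here, and "the series" means these few. Any claim that something is new, unique, unknown or untested is made for them only; others in the source may bear on it.

Measured so far in an assay on microsomes for inhibition of acyl-CoA:cholesterol acyltransferase (Oryctolagus cuniculus); on this read-out lower numbers stand for stronger inhibition and higher numbers for weaker inhibition:
compound 1, `CC(C)c1ccc(C2(CNC(=O)Nc3c(C(C)C)cccc3C(C)C)CCCC2)cc1`, gives 48 nM;
compound 2, `CC(C)c1cccc(C(C)C)c1NC(=O)NCC1(c2ccc(Cl)cc2)CCCC1`, gives 32 nM;
compound 3, `CC(C)c1cccc(C(C)C)c1NC(=O)NCC1(c2ccccc2C(F)(F)F)CCCC1`, gives 18 nM.

Compound 3 holds the lowest of the three numbers in this assay. Its separation from compound 2 is a 1.8-fold lower number from compound 2 to compound 3 (0.25 log units; within the scatter), which stays within the scatter, while its separation from compound 1 is a 2.7-fold lower number from compound 1 to compound 3 (0.43 log units; beyond the scatter), which lies beyond it. Compound 4, `CC(C)c1cccc(C(C)C)c1NC(=O)NCC1(c2ccc([N+](=O)[O-])cc2)CCCC1`, has not yet been measured. It differs from compound 3 in one place: 4-nitrophenyl in place of 2-(trifluoromethyl)phenyl on a saturated ring carbon.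

Among the compounds with values here, two measured steps bear on this change, as both also swap the group on that same saturated ring carbon. Replacing 4-isopropylphenyl with 2-(trifluoromethyl)phenyl gave a 2.7-fold lower number from compound 1 to compound 3 (0.43 log units; beyond the scatter), and replacing 4-chlorophenyl with 2-(trifluoromethyl)phenyl gave a 1.8-fold lower number from compound 2 to compound 3 (0.25 log units; within the scatter). Compound 4 carries 4-nitrophenyl, and the two compounds carrying 4-isopropylphenyl and 4-chlorophenyl show numbers at or above that of compound 3, with only compound 1 beyond the scatter. A small step towards a higher number is therefore expected for compound 4, one that may not clear the scatter. Compound 4 is expected to give 35 nM, within a range from 15 nM to 85 nM. This corresponds to an expected step of a 1.9-fold higher number from compound 3 to compound 4 (0.29 log units; within the scatter).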

Compound 4, half-maximal inhibitory concentration: 131 nM
Compound 4: the middle estimate sits 3.7-fold (0.57 log units) below what was measured; the whole stated range lies below it.
By their numbers in this assay, from the lowest: compounds 3, 2 and 1 (each within the scatter of the next, the first and the last beyond it); then compound 4.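

In this assay, the group on the saturated ring carbon can shift the number much further than the first three compounds suggested: 4-nitrophenyl in place of 2-(trifluoromethyl)phenyl gives a 7.3-fold higher number from compound 3 to compound 4 (0.86 log units; beyond the scatter), the largest step seen at this position. The change also shows up when only the group carried on the phenyl ring differs, since nitro in place of chloro gives a 4.1-fold higher number from compound 2 to compound 4 (0.61 log units; beyond the scatter) and nitro in place of isopropyl gives a 2.7-fold higher number from compound 1 to compound 4 (0.44 log units; beyond the scatter), whereas chloro in place of isopropyl stayed within the scatter. Compound 4 therefore has the highest number of the four, with its step from each of the others lying beyond the scatter, and nitro stands apart from both chloro and isopropyl.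

Nothing measured here explains why the nitro compound gives the higher number. Going by these compounds, it remains open whether an amine, a nitrile or a carboxylic acid on that phenyl ring would read like nitro or like chloro, and how trifluoromethyl would read in the place that nitro holds in 4-nitrophenyl.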